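From 2-Methoxyphenyl to 3-Methoxyphenyl on a Shared Core

This account rests on a few compounds, and the source may have more. Where it says the series, first, only, none or still open, it means among the compounds named here.

Compound 1 `COc1ccccc1NC1=CC(=O)c2c(nc3n2[C@H]2OC[C@@H](O)[C@H]2OC3)C1=O` gives > 4000 nM as a limit
Compound 2 `O=C1C=C(Nc2cccc(F)c2)C(=O)c2c1nc1n2[C@H]2OC[C@@H](O)[C@H]2OC1` gives 7030 nM as a number
Compound 3 `O=C1C=C(NC2CCCC2)C(=O)c2c1nc1n2[C@H]2OC[C@@H](O)[C@H]2OC1` gives > 16000 nM as a limit

In a functional assay on ECa-109 cells for inhibition, with ECa-109 cell line (Homo sapiens) as the target, read by sulforhodamine B assay (a higher number here means a weaker inhibitor, a lower number a stronger inhibitor), compound 1 stands at > 4000 nM as a limit and not a number, so its true position is not known. Compound 4 `COc1cccc(NC2=CC(=O)c3c(nc4n3[C@H]3OC[C@@H](O)[C@H]3OC4)C2=O)c1` has not yet been measured and differs from compound 1 in one place. That difference is 3-methoxyphenyl in place of 2-methoxyphenyl on an amine nitrogen and, in words, it is 3-methoxyphenyl in place of 2-methoxyphenyl on an amine nitrogen.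

Among the compounds with values here, only one measured step comes near this change. It is an at least 2.2-fold higher number from compound 2 to compound 3 (0.35 log units; beyond the scatter) and it replaces 3-fluorophenyl with cyclopentyl, so it does not move a group around a phenyl ring. Within the data shown here, no measured step gives the size of such a move, and no step beyond the scatter is therefore expected in this assay here. The best numerical anchor is compound 2, which has 3-fluorophenyl on the amine nitrogen and gives 7030 nM in this series. The expected step that the limit leaves unreadable from compound 1 to compound 4 is only a rough estimate, since it starts from a limit. Compound 4 is expected at 7000 nM, with 3000 nM to 16000 nM as the estimated range.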

Compound 4, half-maximal inhibitory concentration: 3340 nM
Compound 4: middle estimate off by 2.1-fold (0.32 log units), on the high side; measured number inside the range.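

In this assay compound 4 gives 3340 nM and compound 2, which carries 3-fluorophenyl on the same amine nitrogen, gives 7030 nM, so the shared core now has a measured number with a methoxyphenyl group as well as with 3-fluorophenyl. Moving from 2-methoxyphenyl to 3-methoxyphenyl reads as an at least 1.1-fold lower number from compound 1 to compound 4 (0.07 log units; that floor lies within the scatter), which gives only a floor for the step, so these compounds neither show a change beyond the scatter nor rule one out. The true size of this step stays unknown because compound 1 has only a limit: the limit of > 4000 nM in this assay, at which 1 of the 4 values shown sits.

Going by these compounds, it remains open whether compound 1, with a number in place of its limit, would differ from compound 4 by more than the scatter. On these data alone, it is also open how a plain phenyl, a benzyl group or a morpholine on this amine nitrogen would stand in this assay, and whether any of them would give a number rather than a limit.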